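Trichloromethyl for Nitro: Expected Acid Dissociation of Compound 4

The source may hold more compounds than are shown below. What is called first, only, known or untested is meant among the compounds shown, and "the series" means these compounds.

Of the compounds shown here, three have been measured in a physicochemical assay for acid dissociation. Compound 1 `O=[N+]([O-])c1ccc(Oc2ccc(NC(=S)Oc3ccc(O)cc3)cc2)cc1` gives 9.23, compound 2 `Oc1ccc(OC(=S)Nc2ccc(Nc3ccc(C(Cl)(Cl)Cl)cc3)cc2)cc1` gives 9.23, and compound 3 `O=[N+]([O-])c1ccc(Nc2ccc(NC(=S)Oc3ccc(O)cc3)cc2)cc1` gives 9.22; the three numbers lie within the scatter of one another. Compound 3 and compound 2 differ by trichloromethyl in place of nitro on an aromatic carbon, and this change brought a number 0.01 log units higher from compound 3 to compound 2 (within the scatter). The difference between the core of compound 1 and the core of compound 3 is not broken down here. Compound 4 `Oc1ccc(OC(=S)Nc2ccc(Oc3ccc(C(Cl)(Cl)Cl)cc3)cc2)cc1` has not yet been measured; it differs from compound 1 by trichloromethyl in place of nitro on an aromatic carbon, the same change, in the same place. Because the earlier change gave only a number 0.01 log units higher from compound 3 to compound 2 (within the scatter), compound 4 is expected to show no change at the digits printed from compound 1 to compound 4 (within the scatter) in this assay. Compound 4 is therefore estimated at 9.23, most likely between 8.93 and 9.53.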

Compound 4, acid dissociation constant: 9.24
Estimate against measurement, compound 4: 0.01 log units below; measured number inside the range.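

In this assay, trichloromethyl in place of nitro on an aromatic carbon gave a number 0.01 log units higher from compound 1 to compound 4 (within the scatter) on one core and a number 0.01 log units higher from compound 3 to compound 2 (within the scatter) on the other, so both steps lie within the scatter and the change carried from one core to the other in this pair of cores. This shows agreement across these two pairs only, and it does not show that the change would stay within the scatter on any further core in the series. Nothing shown bears on the reason for this agreement.

The compounds shown hold only nitro or trichloromethyl at this place, on two cores. On these data alone, how an amine or a carboxylic acid there would read in this assay remains open.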